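The source may hold more compounds than are shown below. What is called first, only, known or untested is meant among the compounds shown, and "the series" means these compounds.

Compound 3 `NCC(=O)NC[C@@H]1CCCc2cc(S(=O)(=O)c3cccc(F)c3)ccc21` stands second highest of the three numbers measured in an assay on isolated protein for displacement of a labelled ligand from 5-hydroxytryptamine receptor 6 (Homo sapiens); a higher number here means a weaker inhibitor, a lower number a stronger inhibitor. Its value, 0.316 nM, sits between those of its two neighbours. Compound 1 `NC[C@@H]1CCCc2cc(S(=O)(=O)c3cccc(F)c3)ccc21`, the parent with an unsubstituted amine, gives 0.0794 nM, and the step of a 4.0-fold higher number from compound 1 to compound 3 (0.60 log units; beyond the scatter) is modest. Compound 2 `CN(C)S(=O)(=O)NC[C@@H]1CCCc2cc(S(=O)(=O)c3cccc(F)c3)ccc21`, carrying a dimethylsulfamoyl group on the amine nitrogen, gives 2 nM, so that a 25-fold higher number from compound 1 to compound 2 (1.40 log units; beyond the scatter) is large, while a 6.3-fold lower number from compound 2 to compound 3 (0.80 log units; beyond the scatter) recovers most of that loss.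

Compound 4 `CC(C)(O)C(=O)NC[C@@H]1CCCc2cc(S(=O)(=O)c3cccc(F)c3)ccc21` differs from compound 3 at the carbonyl carbon: 1-hydroxy-1-methylethyl in place of aminomethyl on a carbonyl carbon. Going by the values given here, no measured pair covers this exchange directly. The amide linkage that compound 3 carries is kept, and the nearest guide is that an acyl group on the nitrogen is tolerated far better than a sulfamoyl one. With one donor and one acceptor leaving and one of each entering, the expected step in this assay is a 1.9-fold higher number from compound 3 to compound 4 (0.28 log units; within the scatter), a small shift toward a weaker number that may not exceed the scatter. Compound 4 is therefore expected to give 0.6 nM, within 0.15 nM to 2.5 nM.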

Compound 4, inhibition constant: 2 nM
The estimate for compound 4 lay 3.3-fold (0.52 log units) below the measured number; the measured number falls inside the stated range.
By their numbers in this assay, from the lowest: compound 1; then compound 3; then compounds 2 and 4 (each within the scatter of the next).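

In this assay, the exchange on the carbonyl carbon is not neutral (a 6.3-fold higher number from compound 3 to compound 4 (0.80 log units; beyond the scatter)), even though the leaving aminomethyl and the entering 1-hydroxy-1-methylethyl have the same hydrogen-bond donor and acceptor counts. An acyl group on the amine nitrogen therefore does not by itself give the better number seen for compound 3: the (1-hydroxy-1-methylethyl)carbonyl group matches the dimethylsulfamoyl group (no change at the digits printed from compound 2 to compound 4 (within the scatter)) and stands as far from the unsubstituted parent (a 25-fold higher number from compound 1 to compound 4 (1.40 log units; beyond the scatter)). No measurement shown here accounts for this step.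

The compounds shown leave open whether the amine nitrogen of aminomethyl or the branched carbons of 1-hydroxy-1-methylethyl matter more. A hydroxymethyl or a 1-amino-1-methylethyl group on the same carbonyl carbon would separate the two.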